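Chain-extended aminosugar triazoles against EC9706 cells

The source may hold more compounds than are shown below. What is called first, only, known or untested is meant among the compounds shown, and "the series" means these compounds.

Three compounds in the series share a triazole-linked aminosugar core and differ in the length of the saturated chain on the aromatic nitrogen, and in one case in the core itself. Compound 1 `CCCCCCCCCCCCCCCCn1cc(COC[C@@H]2OC[C@H](N)[C@@H]2O)nn1` gives 20000 nM in a functional assay on EC9706 cells (Homo sapiens) for antiproliferative activity, read by MTT assay, with a stated time of 48 h; a lower number here means a stronger inhibitor, a higher number a weaker inhibitor. Compound 2 `CCCCCCCCCCCCCCCCCCn1cc(COC[C@@H]2OC[C@H](N)[C@@H]2O)nn1` carries the change ethyl in place of hydrogen on a saturated chain carbon, ten or more bonds along the chain from an aromatic nitrogen relative to compound 1, and in this assay compound 2 gives 17800 nM, so that a 1.1-fold lower number from compound 1 to compound 2 (0.05 log units; within the scatter). The two numbers sit together and no order is read into them.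

Compound 3 `CCCCCCCCCCCCCCn1cc(COC[C@@H]2OC[C@H](N)[C@H]2O)nn1` has a different core; the difference between its core and the core of compound 1 is not broken down here. In this assay compound 3 gives 6680 nM, the lowest number of the three, beyond the scatter of both compound 1 and compound 2.

Compound 4 `CCCCCCCCCCCCCCCCn1cc(COC[C@@H]2OC[C@H](N)[C@H]2O)nn1` stands to compound 3 as compound 2 stands to compound 1: the change is ethyl in place of hydrogen on a saturated chain carbon, ten or more bonds along the chain from an aromatic nitrogen, the same kind of change, at the same place, on the core of compound 3 rather than the core of compound 1. Within the data shown here, the only measured instance of this change is the one from compound 1 to compound 2, which stayed within the scatter. The step from compound 3 to compound 4 is therefore expected to be of similar size, a 1.1-fold lower number from compound 3 to compound 4 (0.03 log units; within the scatter), because a 1.1-fold lower number from compound 1 to compound 2 (0.05 log units; within the scatter). On that basis compound 4 is estimated at 6200 nM in this assay, with the expected range running from 3000 nM to 13000 nM, anchored on compound 3 at 6680 nM.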

Compound 4, half-maximal inhibitory concentration: 6310 nM
Beside the measured number, compound 4's estimate is 1.0-fold (0.01 log units) below it, and the stated range covers the measured number.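

In this assay, the change of ethyl in place of hydrogen on a saturated chain carbon, ten or more bonds along the chain from an aromatic nitrogen, reads the same on both cores: the same change on two cores in this assay, a 1.1-fold lower number (0.05 log units; within the scatter) from compound 1 to compound 2 and a 1.1-fold lower number (0.02 log units; within the scatter) from compound 3 to compound 4, 1.1-fold (0.03 log units) apart, within the scatter of two such steps

The new step, a 1.1-fold lower number from compound 3 to compound 4 (0.02 log units; within the scatter), stays within the scatter as the earlier one did, so what carries from one core to the other is the absence of a readable effect; this does not show that a step of real size would carry over, and two cores are a narrow base for any rule.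

The larger step in the series, a 3.2-fold lower number from compound 1 to compound 4 (0.50 log units; beyond the scatter), is modest and involves no change of chain, with one stereocentre at a saturated ring carbon drawn S in the first compound and R in the second, and it rests on: the fact that compounds 1 and 4 differ only in the configuration as drawn

Open questions are whether a much shorter chain such as hexyl, or a chain ending in an amine or a carboxylic acid, would give a step beyond the scatter on either core. Also open is how the other two stereo elements bear on the number, since only one configuration difference is shown here.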